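Phenyl in Place of Methoxycarbonyl on a Carbonyl Carbon

The compounds below may be only part of what the source reports. "The series", "measured", "known", "first", "only" and "open" are said of these compounds alone.

In a functional assay on HUVEC cells (Homo sapiens) for inhibition (on this read-out higher numbers stand for weaker inhibition and lower numbers for stronger inhibition), compound 1 `COc1cc(/C=C/C(=O)c2cccc(NC(=O)c3cccs3)c2)ccc1O` gives 0.38 ug/mL and compound 2 `COC(=O)C(=O)Nc1cccc(C(=O)/C=C/c2ccc(O)c(OC)c2)c1` gives 1.5 ug/mL, the higher of the two numbers. Compound 3 `COc1cc(/C=C/C(=O)c2cccc(NC(=O)c3ccccc3)c2)ccc1O` carries phenyl in place of methoxycarbonyl on a carbonyl carbon. Among the measured compounds shown here, the one measured step that bears on this is a 3.9-fold higher number from compound 1 to compound 2 (0.60 log units; beyond the scatter), with methoxycarbonyl in place of thiophen-2-yl. Phenyl, like thiophen-2-yl, is a ring, so a move of similar size back toward a lower number seems likely. The expected step is a 3.0-fold lower number from compound 2 to compound 3 (0.48 log units; beyond the scatter). For compound 3 the estimated value is 0.5 ug/mL, within an expected range of 0.17 ug/mL to 1.5 ug/mL.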

Compound 3, half-maximal inhibitory concentration: 0.37 ug/mL
Compound 3: the middle estimate sits 1.4-fold (0.13 log units) above what was measured; measured number inside the range.
By their numbers in this assay, from the lowest: compounds 3 and 1 (each within the scatter of the next); then compound 2.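

In this assay, a 4.1-fold lower number from compound 2 to compound 3 (0.61 log units; beyond the scatter) shows that phenyl, like thiophen-2-yl, gives a lower number than methoxycarbonyl on this carbonyl carbon. Exchanging one aromatic ring for the other makes no real difference, with a 1.0-fold lower number from compound 1 to compound 3 (0.01 log units; within the scatter) lying within the scatter, so this position accepts either ring equally well. Nothing available explains these results. Still open, from the compounds shown here alone, is whether an aromatic ring is needed here at all, or whether cyclohexyl or a plain butyl chain would serve as well. A ring carrying an amine or a carboxylic acid would also test how much this position tolerates.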